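Replacing bromo with 4-methoxyphenyl on a thiophene core

The compounds below may be only part of what the source reports. "The series", "measured", "known", "first", "only" and "open" are said of these compounds alone.

Measured in an assay on CHO-K1 cells for displacement of a labelled ligand from adenosine receptor A1 (Homo sapiens), tested at 10 uM; on this read-out lower numbers stand for less inhibition and higher numbers for more inhibition at the one concentration tested (going by the name of the read-out):
- compound 1 `Nc1sc(Br)c(-c2cccc(C(F)(F)F)c2)c1C(=O)c1ccccc1`: 47.5%
- compound 2 `Nc1sc(-c2ccccc2)c(-c2cccc(C(F)(F)F)c2)c1C(=O)c1ccccc1`: 82.4%
- compound 3 `CC(=O)c1ccc(-c2sc(N)c(C(=O)c3ccccc3)c2-c2cccc(C(F)(F)F)c2)cc1`: 25.6%

Among these three numbers compound 1 stands second highest, beyond the scatter below compound 2 and beyond the scatter above compound 3. Compound 4 `COc1ccc(-c2sc(N)c(C(=O)c3ccccc3)c2-c2cccc(C(F)(F)F)c2)cc1` has not yet been measured in this assay. It differs from compound 1 in one place: 4-methoxyphenyl in place of bromo on an aromatic carbon.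

Two measured steps start from the same bromo position of compound 1. The step of a number 34.9 percentage points higher from compound 1 to compound 2 (beyond the scatter) shows that a plain aromatic ring at this position raises inhibition by a large amount. The step of a number 21.9 percentage points lower from compound 1 to compound 3 (beyond the scatter) shows that the same ring carrying an acetyl group lowers it by a modest amount, and a number 56.8 percentage points lower from compound 2 to compound 3 (beyond the scatter) shows how far acetyl pulls the number down from the plain ring. A methoxy group is neither hydrogen nor acetyl, so compound 4 is expected to land between compound 2 and compound 3, with a wide range. The expected step is a number 7.5 percentage points higher from compound 1 to compound 4 (within the scatter), giving an estimate for compound 4 of 55%, between 30% and 80%.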

Compound 4, a percentage reported as inhibition, at one concentration (the size of the read-out at that concentration, not a potency): 65.2%
Compound 4: the middle estimate sits 10.2 percentage points below what was measured; the measured number falls inside the stated range.
By their numbers in this assay, from the lowest: compound 3; then compound 1; then compound 4; then compound 2.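

In this assay, the new result shows that a substituted phenyl ring at this place can still outdo bromo, a number 17.7 percentage points higher from compound 1 to compound 4 (beyond the scatter), so the drop seen with 4-acetylphenyl is not shared by every group on that ring. Methoxy still gives a lower number than the plain phenyl ring, a number 17.2 percentage points lower from compound 2 to compound 4 (beyond the scatter), yet it stands well clear of acetyl, a number 39.6 percentage points higher from compound 3 to compound 4 (beyond the scatter). The number at this place therefore depends on which group the phenyl ring carries, not only on the ring being there.

The compounds shown leave open whether an amine or a carboxylic acid on that phenyl ring would stay near compound 2 or fall toward compound 3, and whether a longer chain in place of methoxy would give a similar number. Nothing available here explains why these groups differ.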